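This account rests on a few compounds, and the source may have more. Where it says the series, first, only, none or still open, it means among the compounds named here.

Compound 1 `CC(C(=O)NCc1ccc(C(F)(F)F)nc1)c1ccc(NS(C)(=O)=O)c(F)c1` gives in a functional assay on CHO-K1 cells for antagonist activity at transient receptor potential cation channel subfamily V member 1 (Homo sapiens), read by FLIPR (on this read-out lower numbers stand for stronger inhibition and higher numbers for weaker inhibition), the result "not active" (no number reported), with no number reported. Compound 2 `CC(C(=O)NCc1ccc(C(F)(F)F)nc1NCc1ccccc1)c1ccc(NS(C)(=O)=O)c(F)c1` gives in this assay a value of 203 nM. Among the measured compounds shown here, compound 3 `CC(C(=O)NCc1ccc(C(F)(F)F)nc1N(C)c1ccccc1)c1ccc(NS(C)(=O)=O)c(F)c1` gives in this assay a value of 57.4 nM, the lowest of the two numbers that are available; its nearest neighbour is compound 2, and the only single-point step in the set is a 3.5-fold lower number from compound 2 to compound 3 (0.55 log units; beyond the scatter).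

Compound 4 `CCCCOC1CCN(c2nc(C(F)(F)F)ccc2CNC(=O)C(C)c2ccc(NS(C)(=O)=O)c(F)c2)CC1` differs from compound 3 by a group of 11 heavy atoms (9 carbon, 1 nitrogen, 1 oxygen; one six-membered non-aromatic ring with 1 hetero atom) in place of a group of 8 heavy atoms (7 carbon, 1 nitrogen; one six-membered aromatic ring of carbon only), on an aromatic carbon. The step from compound 2 to compound 3 bears on this change only in so far as it concerns the same aromatic carbon, and it was modest. For the measured compounds named here, the group that enters compound 4, with its non-aromatic ring, has no precedent in the measured set, so the direction of the change cannot be read from the data, and the expectation is a step of about the same order as the one seen, in either direction, with a wide range.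

For compound 4 the estimate in this assay is 80 nM, expected to fall between 20 nM and 400 nM. This estimate implies the step of a 1.4-fold higher number from compound 3 to compound 4 (0.14 log units; within the scatter), which is expected to stay near the edge of the scatter.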

Compound 4, half-maximal inhibitory concentration: 28.2 nM
Compound 4: middle estimate off by 2.8-fold (0.45 log units), on the high side, and the stated range covers the measured number.
By their numbers in this assay, from the lowest: compound 4; then compound 3; then compound 2.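

On the aromatic carbon next to the ring nitrogen, the earlier numbers came only from groups carrying a six-membered aromatic ring of carbon, and compound 4 shows that such a ring is not needed there for activity in this assay. The group with a six-membered non-aromatic ring gives a 2.0-fold lower number from compound 3 to compound 4 (0.31 log units; beyond the scatter) and a 7.2-fold lower number from compound 2 to compound 4 (0.86 log units; beyond the scatter), both beyond the scatter, so compound 4 now holds the lowest of the three numbers. Together with compound 1, which carries neither group and gives "not active" (no number reported), this shows that the position accepts two quite different kinds of group, and that a larger group with an oxygen and a non-aromatic ring gives up nothing against the methyl(phenyl)amino group. No measurement here accounts for the lower number.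

The compounds shown do not separate the contribution of the non-aromatic ring from that of the oxygen or the chain it carries, and they leave open whether a small dimethylamino group or a longer alkyl ether chain on the same carbon would give a lower or a higher number.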